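The source may report more compounds than this note shows. Statements on the series, on what has been measured and on what is new or still open speak of the compounds shown alone.

Compound 1 `CC(=O)OC[C@H]1O[C@@H](n2cc(-c3cn(Cc4ccc(C(C)C)cc4)nn3)c(=O)[nH]c2=O)C[C@@H]1OC(C)=O` gives 92.2% in a functional assay on ACHN cells (Homo sapiens) for cytotoxicity, read by sulforhodamine B assay, tested at 10 uM; on this read-out lower numbers stand for less inhibition and higher numbers for more inhibition at the one concentration tested (going by the name of the read-out); compound 2 `CC(=O)OC[C@H]1O[C@@H](n2cc(-c3cn(Cc4ccccc4)nn3)c(=O)[nH]c2=O)C[C@@H]1OC(C)=O` gives 99%.

Compound 2 stands highest of the two numbers, yet the step of a number 6.8 percentage points higher from compound 1 to compound 2 (within the scatter) does not separate the pair. Compound 3 `CC(=O)OC[C@H]1O[C@@H](n2cc(-c3cn(Cc4ccc(C(C)(C)C)cc4)nn3)c(=O)[nH]c2=O)C[C@@H]1OC(C)=O` differs from compound 2 by tert-butyl in place of hydrogen on an aromatic carbon. Among the compounds with values here, only one measured step speaks to this place on the ring: a number 6.8 percentage points higher from compound 1 to compound 2 (within the scatter), where a bulky group left the same aromatic carbon with no step beyond the scatter. A comparable change is therefore expected to leave the read-out where it is, a number 5 percentage points lower from compound 2 to compound 3 (within the scatter). Compound 3 is estimated at 94%, within 80% to 100%.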

Compound 3, a percentage reported as inhibition, at one concentration (the size of the read-out at that concentration, not a potency): 97.2%
Compound 3: the middle estimate sits 3.2 percentage points below what was measured; measured number inside the range.
By their numbers in this assay, from the lowest: compounds 1, 3 and 2 (each within the scatter of the next).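

In this assay, tert-butyl on this aromatic carbon gives a number 1.8 percentage points lower from compound 2 to compound 3 (within the scatter), so a second bulky group also shows no separation from hydrogen. Adding one methyl to isopropyl to make tert-butyl gives a number 5 percentage points higher from compound 1 to compound 3 (within the scatter), so these two branched groups cannot be told apart either. Nothing on hand explains this result.

As far as these compounds go, how a carboxylic acid or an amine on this carbon would read remains open. Results at one concentration also give no potency, so any potency differences among the three compounds remain unknown.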